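Working notes: tert-butyl in place of ethynyl

The compounds below may be only part of what the source reports. "The series", "measured", "known", "first", "only" and "open" are said of these compounds alone.

Measured in an ADME assay on WI-38 cells (Homo sapiens) for cytotoxicity, read by MTT assay, with a stated time of 72 h; a lower number here means a stronger inhibitor, a higher number a weaker inhibitor:
- compound 1 `O=C(CCc1cccc2c1B(O)OC2)Nc1ccc(I)cc1`: 49000 nM
- compound 2 `Cc1ccc(NC(=O)CCc2cccc3c2B(O)OC3)cc1`: > 100000 nM (a limit)
- compound 3 `C#Cc1ccc(NC(=O)CCc2cccc3c2B(O)OC3)cc1`: > 100000 nM (a limit)

Compound 3 stands at > 100000 nM, which is a limit and not a number. This is the limit of > 100000 nM in this assay, at which 2 of the 3 values shown sit, and compound 2 is the other compound there.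

Compound 4 `CC(C)(C)c1ccc(NC(=O)CCc2cccc3c2B(O)OC3)cc1` carries tert-butyl in place of ethynyl on an aromatic carbon.

Methyl in place of iodo gave an at least 2.0-fold higher number from compound 1 to compound 2 (0.30 log units; that floor lies within the scatter). Ethynyl in place of iodo gave an at least 2.0-fold higher number from compound 1 to compound 3 (0.30 log units; that floor lies within the scatter). Ethynyl in place of methyl gave a step that the two limits leave unreadable from compound 2 to compound 3. Among the measured compounds shown here, no measured step involves tert-butyl, so these bear on the change only loosely. For the measured compounds named here, the sole number is that of compound 1, at 49000 nM, and the expectation leans on it.

The expected step in this assay is an at least 1.3-fold lower number from compound 3 to compound 4 (0.12 log units; that floor lies within the scatter), small, towards a lower number and read against a limit. A further limit for compound 4 is also quite possible. For compound 4 the estimate is 75000 nM, with an expected range of 30000 nM to 150000 nM.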

Compound 4, half-maximal inhibitory concentration: 55000 nM
The estimate for compound 4 lay 1.4-fold (0.13 log units) above the measured number; the measured number falls inside the stated range.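

Compound 4 gives a second true number for this aromatic carbon in this assay, and the remaining readings are limits: the limit of > 100000 nM in this assay, at which 2 of the 4 values shown sit. Tert-butyl gives an at least 1.8-fold lower number from compound 3 to compound 4 (0.25 log units; that floor lies within the scatter), and in place of methyl it gives an at least 1.8-fold lower number from compound 2 to compound 4 (0.25 log units; that floor lies within the scatter), so the series now shows a measurable reading with a non-halogen group at this position, although neither step clears the scatter. Tert-butyl in place of iodo gives a 1.1-fold higher number from compound 1 to compound 4 (0.05 log units; within the scatter), so compound 1 and compound 4 cannot be told apart in this assay, and the number at compound 1 no longer depends on iodo alone.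

The step between compound 2 and compound 3 still cannot be read. As far as these compounds go, how an amine or a carboxylic acid on this aromatic carbon would read remains open, as does the effect of a longer chain in place of tert-butyl.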